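Aryl swap at the methine carbon of the shared core

The compounds below may be only part of what the source reports. "The series", "measured", "known", "first", "only" and "open" are said of these compounds alone.

Compound 2 `COc1cccc(C(C2=C(O)C(=O)c3ccccc3C2=O)c2c[nH]c3ccccc23)c1` and compound 1 `O=C1C(O)=C(C(c2ccc(Cl)cc2)c2c[nH]c3ccccc23)C(=O)c2ccccc21` share a core and differ only in the aryl group on the methine carbon. In a functional assay on HeLa cells (Homo sapiens) for cytotoxicity, read by MTT assay, with a stated time of 48 h (on this read-out higher numbers stand for weaker inhibition and lower numbers for stronger inhibition), compound 1 gives 37000 nM and compound 2 gives 25600 nM. The step of a 1.4-fold lower number from compound 1 to compound 2 (0.16 log units; within the scatter) is within the scatter, so compound 2 stands at the lower of the two numbers without standing apart from compound 1.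

Compound 3 `O=C1C(O)=C(C(c2cccc([N+](=O)[O-])c2)c2c[nH]c3ccccc23)C(=O)c2ccccc21` carries the change (nitro in place of methoxy on an aromatic carbon), on an aromatic carbon of a six-membered aromatic ring of carbon only, meta to a large group. Going by the values given here, no measured step bears on a nitro-for-methoxy exchange. Among the compounds with values here, the only step seen, a 1.4-fold lower number from compound 1 to compound 2 (0.16 log units; within the scatter), was a different aryl substituent change and it was within the scatter, which gives no ground to expect a large move in this assay in either direction. The expected step of a 1.0-fold lower number from compound 2 to compound 3 (0.01 log units; within the scatter) is therefore small. For compound 3 the estimated value in this assay is 25000 nM, with a range from 10000 nM to 60000 nM.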

Compound 3, half-maximal inhibitory concentration: 24900 nM
Estimate against measurement, compound 3: 1.0-fold (0.00 log units) above, and the stated range covers the measured number.
By their numbers in this assay, from the lowest: compounds 3, 2 and 1 (each within the scatter of the next).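

In this assay, going by these compounds alone, the exchange of nitro for methoxy on an aromatic carbon, meta to a large group, gives a 1.0-fold lower number from compound 2 to compound 3 (0.01 log units; within the scatter), so this is the first step read at one fixed place on the aryl ring. The other new step, a 1.5-fold lower number from compound 1 to compound 3 (0.17 log units; within the scatter), comes with 3-nitrophenyl in place of 4-chlorophenyl, so the read-out does not separate 4-chlorophenyl, 3-methoxyphenyl and 3-nitrophenyl at the methine carbon, and neither a change of substituent at one place nor a change of the whole aryl group has yet gone beyond the scatter. Nothing at hand explains this flat result or bears on what lies behind it.

Going by these compounds, whether an amine or a carboxylic acid on the same aromatic carbon, or a longer chain there, would give a step beyond the scatter remains open, as does the reading for a plain phenyl group at the methine carbon. The shared core itself stays constant across these compounds, so what a change elsewhere on it would do to the number is also unknown.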